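A few compounds are considered here, and "the series" means these few. Any claim that something is new, unique, unknown or untested is made for them only; others in the source may bear on it.

Measured so far:
Compound 1 `Cc1cc(C)c2cccc(OCc3c(Cl)ccc(S(=O)(=O)NC4(C(=O)N5CCN(C(=O)[C@H](CCCC[N+](C)(C)C)[N+](C)(C)C)CC5)CCCC4)c3Cl)c2n1`: < 10000 nM
Compound 2 `Cc1cc(C)c2cccc(OCc3c(Cl)ccc(S(=O)(=O)NC4(C(=O)N5CCN(C(=O)[C@H](CCCCN)[N+](C)(C)C)CC5)CCCC4)c3Cl)c2n1`: < 10000 nM

In an assay on isolated protein for binding affinity to B1 bradykinin receptor (Homo sapiens) (on this read-out lower numbers stand for stronger inhibition and higher numbers for weaker inhibition), compound 1 gives < 10000 nM, which is a limit of the assay and not a number. In this assay compound 2 gives < 10000 nM, again a limit. Both values sit at the limit of < 10000 nM in this assay, at which 2 of the 2 values shown sit, so compound 2 stands at that limit with no number of its own, and the measured step that the two limits leave unreadable from compound 1 to compound 2 cannot be read, since it joins two limits.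

Compound 3 `Cc1cc(C)c2cccc(OCc3c(Cl)ccc(S(=O)(=O)NC4(C(=O)N5CCN(C(=O)[C@@H](N)CCC[N+](C)(C)C)CC5)CCCC4)c3Cl)c2n1` has not yet been measured. It differs from compound 2 by a group of 9 heavy atoms (7 carbon, 2 nitrogen; no ring) in place of a group of 10 heavy atoms (8 carbon, 2 nitrogen; no ring), on a carbonyl carbon. Within the data shown here, the only measured step that touches this part of the molecule, a step that the two limits leave unreadable from compound 1 to compound 2, is of unreadable size, so it gives no direction for the change. With both neighbours at the limit, compound 3 is expected to land at or near the same limit, and the step of a number no lower from compound 2 to compound 3 (the limit leaves the size open) is estimated to be none beyond the scatter. Compound 3 is therefore estimated at 10000 nM, within a range from 3000 nM to 30000 nM.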

Compound 3, inhibition constant: < 10000 nM
Compound 3 was reported as a limit; the forecaster's own chance of this, stated with the estimate: 75%; the middle value sits exactly at the limit.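

In this assay, among these compounds, compound 3 gives < 10000 nM, which is a limit of the assay and not a number; with compound 2 also at a limit, no step between them can be read. What compound 1, compound 2 and compound 3 leave open is the actual affinity of each, and so whether these changes matter at all, as all of them stand at one limit: the limit of < 10000 nM in this assay, at which 3 of the 3 values shown sit.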